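Furan-2-yl in Place of 3-Methylphenyl: Expected Receptor Binding

A few compounds are considered here, and "the series" means these few. Any claim that something is new, unique, unknown or untested is made for them only; others in the source may bear on it.

Measured compounds:
compound 1 `COc1ccccc1-c1sc(N)c(C(=O)c2ccc(Cl)cc2)c1CC(C)(C)C`: 1%
compound 2 `Cc1cccc(-c2sc(N)c(C(=O)c3ccc(Cl)cc3)c2CC(C)(C)C)c1`: 1%

In an assay on CHO cells for displacement of a labelled ligand from adenosine receptor A1 (Homo sapiens), read by scintillation counting, tested at 10 uM (a lower number here means less inhibition, a higher number more inhibition at the concentration tested (going by the name of the read-out)), compound 1 gives 1%, and compound 2 gives 1%. Compound 2 therefore stands level with compound 1 at the digits shown, the step of no change at the digits printed from compound 1 to compound 2 (within the scatter) lying within the scatter. Compound 3 `CC(C)(C)Cc1c(-c2ccco2)sc(N)c1C(=O)c1ccc(Cl)cc1` has not yet been tested in this assay. It differs from compound 2 in one place: furan-2-yl in place of 3-methylphenyl on an aromatic carbon. Among the measured compounds shown here, the only measured step bears on a change at the same aromatic carbon of the shared core, and it was flat: no change at the digits printed from compound 1 to compound 2 (within the scatter). For the measured compounds named here, nothing among the measured compounds therefore points to a move beyond the scatter, although no measured step shows furan-2-yl itself. Compound 3 is expected to give 2% in this assay, within a range from 0% to 12%. The estimated step from compound 2 to compound 3 is a number 1 percentage points higher from compound 2 to compound 3 (within the scatter), that is, none beyond the scatter.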

Compound 3, a percentage reported as inhibition, at one concentration (the size of the read-out at that concentration, not a potency): 1%
The estimate for compound 3 lay 1 percentage points above the measured number, and the stated range covers the measured number.
By their numbers in this assay, from the lowest: compounds 1, 2 and 3 (each within the scatter of the next).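

At this aromatic carbon, next to the ring sulfur, the series now includes a five-membered aromatic ring with 1 hetero atom as well as six-membered aromatic rings of carbon only, and in this assay furan-2-yl in place of 3-methylphenyl gives no change at the digits printed from compound 2 to compound 3 (within the scatter) at this position. Furan-2-yl in place of 2-methoxyphenyl likewise gives no change at the digits printed from compound 1 to compound 3 (within the scatter), so the flat result holds across both comparisons, even with 5 heavy atoms entering where 7 leave and 1 hydrogen-bond acceptor added in the step from 3-methylphenyl. No available evidence accounts for this flat result.

The compounds shown leave open whether a group without an aromatic ring at this carbon, such as a cyclohexyl ring, a primary amine or a carboxylic acid, would read differently. They also leave open whether a shorter chain in place of the neopentyl group would change the reading.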